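Compound 2 to compound 4: from arylamino to aroylamino

The source may report more compounds than this note shows. Statements on the series, on what has been measured and on what is new or still open speak of the compounds shown alone.

Measured in a functional assay on OVCAR-3 cells (Homo sapiens) for antiproliferative activity, read by MTT assay, with a stated time of 24 h; a higher number here means a weaker inhibitor, a lower number a stronger inhibitor:
- compound 1 `O=C(NNc1ccc(F)cc1)c1cccc(NS(=O)(=O)c2cnc(O)nc2O)c1`: > 20000 nM (a limit of the assay)
- compound 2 `Cc1ccccc1NNC(=O)c1ccccc1NS(=O)(=O)c1cnc(O)nc1O`: > 20000 nM (a limit of the assay)
- compound 3 `O=C(NNC(=O)c1ccccc1F)c1cccc(NS(=O)(=O)c2cnc(O)nc2O)c1`: 10800 nM

Compound 2 gives no number in this assay, only the limit > 20000 nM and no more. It shares that position with one other compound: the limit of > 20000 nM in this assay, at which 2 of the 3 values shown sit.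

Compound 4 `Cc1ccc(C(=O)NNC(=O)c2ccccc2NS(=O)(=O)c2cnc(O)nc2O)cc1` has not yet been measured. It differs from compound 2 by (4-methylphenyl)carbonyl in place of 2-methylphenyl on an amine nitrogen.

Among the compounds with values here, one measured step bears on this change, since it also puts an aryl carbonyl in place of an aryl group on an amine nitrogen. That step is an at least 1.8-fold lower number from compound 1 to compound 3 (0.26 log units; that floor lies within the scatter), and it is only a floor. On the evidence of that step and of compound 3 at 10800 nM, a modest move towards a lower number is expected. Compound 4 may yet stay at the limit.

The expected change is an at least 1.5-fold lower number from compound 2 to compound 4 (0.18 log units; that floor lies within the scatter) in this assay.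

For compound 4 the estimate is 13000 nM, with an expected range from 6000 nM to 30000 nM.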

Compound 4, half-maximal inhibitory concentration: 12900 nM
Beside the measured number, compound 4's estimate is 1.0-fold (0.00 log units) above it, and the stated range covers the measured number.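

In this assay, the change from an aryl group to an aryl carbonyl on this amine nitrogen now appears in a second pair, this one carrying methyl rather than fluorine, with an at least 1.5-fold lower number from compound 2 to compound 4 (0.19 log units; that floor lies within the scatter). Together with an at least 1.8-fold lower number from compound 1 to compound 3 (0.26 log units; that floor lies within the scatter), this means that in both pairs shown the aryl carbonyl compound gives a number while the aryl compound gives only a limit, and neither pair goes against this. Both steps remain floors, and the true size of this one stays unknown, since compound 2 holds only a limit of the assay: the limit of > 20000 nM in this assay, at which 2 of the 4 values shown sit.

The names 2-methylphenyl and 4-methylphenyl also differ, so this step does not separate the carbonyl from the place of the methyl. On these data alone, how an acetyl group or a longer alkyl chain on this nitrogen would read remains open.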